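The source may report more compounds than this note shows. Statements on the series, on what has been measured and on what is new or still open speak of the compounds shown alone.

Measured so far in a functional assay on HT-29 cells (Homo sapiens) for antiproliferative activity, read by MTT assay, with a stated time of 24 h; on this read-out lower numbers stand for stronger inhibition and higher numbers for weaker inhibition:

Compound 1, `COc1ccc(C(=O)/C=C/c2ccc(F)cc2)c2c1C=CC(C)(C)O2`, gives > 10000 nM, which is a limit of the assay and not a number.
Compound 2, `COc1ccc(C(=O)/C=C/c2cccc(Cl)c2)c2c1C=CC(C)(C)O2`, gives > 10000 nM, again a limit of the assay.
Compound 3, `COc1ccc(C(=O)/C=C/c2cccs2)c2c1C=CC(C)(C)O2`, gives > 10000 nM, once more a limit of the assay.

Compound 1 therefore stands nowhere on a scale of numbers: its entry in this assay is a limit only, and the same holds for the other two, all three sitting at the limit of > 10000 nM in this assay, at which 3 of the 3 values shown sit. The steps that swap the aryl group on the double-bonded chain carbon, a step that the two limits leave unreadable from compound 1 to compound 2, a step that the two limits leave unreadable from compound 1 to compound 3 and a step that the two limits leave unreadable from compound 2 to compound 3, are each unreadable in size for that reason.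

Compound 4, `COc1ccc(C(=O)/C=C/c2ccc(O)cc2)c2c1C=CC(C)(C)O2`, differs from compound 1 by hydroxy in place of fluoro on an aromatic carbon. Every measured step bears on it in kind, since each also exchanges the aryl group bound to the double-bonded chain carbon, yet none yields a readable size, so no direction can be taken from them. With all three neighbours at the limit, the expectation for compound 4 is a further limit rather than a number, and any step that the limit leaves unreadable from compound 1 to compound 4 from compound 1 is therefore estimated as unreadable. For compound 4 the value in this assay is estimated at 20000 nM, within 5000 nM to 100000 nM.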

Compound 4, half-maximal inhibitory concentration: > 10000 nM
Compound 4 was reported as a limit; the forecaster's own chance of this, stated with the estimate: 80%; the middle value lies beyond the limit too.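

The steps linking compound 4 with compound 1, compound 2 and compound 3 cannot be read in size, because all four compounds sit at one limit: the limit of > 10000 nM in this assay, at which 4 of the 4 values shown sit.

The compounds shown leave open how far each lies beyond that limit in this assay, and whether any aryl group on the shared core gives a measurable value there.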